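Swapping the nitro group for a fluorine in a new position

A few compounds are considered here, and "the series" means these few. Any claim that something is new, unique, unknown or untested is made for them only; others in the source may bear on it.

Compound 1, `COc1ccc(S(=O)(=O)N2CCc3cccc(-c4ccc([N+](=O)[O-])cc4)c32)cc1`, gives 34 nM in a functional assay on MKN-45 cells (Homo sapiens) for inhibition, with a stated time of 72 h; a lower number here means a stronger inhibitor, a higher number a weaker inhibitor.
Compound 2, `COc1ccc(S(=O)(=O)N2CCc3cccc(-c4ccc(F)cc4)c32)cc1`, gives 79 nM in this assay.
Compound 3, `COc1ccc(S(=O)(=O)N2CCc3cccc(-c4ccccc4)c32)cc1`, gives 117 nM in this assay.

Among these three, compound 1 stands at the lowest number, so it is the strongest inhibitor of the set: its steps to the other two are both beyond the scatter. Compound 4, `COc1ccc(S(=O)(=O)N2CCc3cccc(-c4cccc(F)c4)c32)cc1`, has not yet been measured. It differs from compound 1 in one place: 3-fluorophenyl in place of 4-nitrophenyl on an aromatic carbon.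

Going by the values given here, two measured steps bear on this. Taking the nitro group away and putting a fluorine in its place gave a 2.3-fold higher number from compound 1 to compound 2 (0.37 log units; beyond the scatter), and taking it away for a hydrogen gave a 3.4-fold higher number from compound 1 to compound 3 (0.54 log units; beyond the scatter). Between the fluoro and the hydrogen compounds the difference, a 1.5-fold higher number from compound 2 to compound 3 (0.17 log units; within the scatter), lies within the scatter, so a fluorine in that position added little beyond what hydrogen gives. Nothing measured here shows what a fluorine in the 3-fluorophenyl arrangement does on its own.

The expectation for compound 4 is therefore a modest loss against compound 1, about the size seen with compound 2 and compound 3, that is a 2.8-fold higher number from compound 1 to compound 4 (0.45 log units; beyond the scatter). Compound 4 is estimated at 95 nM, with a likely range from 45 nM to 200 nM.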

Compound 4, half-maximal inhibitory concentration: 84.7 nM
The estimate for compound 4 lay 1.1-fold (0.05 log units) above the measured number, within the range that was stated.
By their numbers in this assay, from the lowest: compound 1; then compounds 2, 4 and 3 (each within the scatter of the next).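

Compound 4 shows that, in this assay, where the fluorine sits on this aromatic ring makes no readable difference, as 3-fluorophenyl and 4-fluorophenyl stay within the scatter (a 1.1-fold higher number from compound 2 to compound 4 (0.03 log units; within the scatter)), and 3-fluorophenyl also cannot be told apart from the plain phenyl (a 1.4-fold lower number from compound 3 to compound 4 (0.14 log units; within the scatter)). The gap to 4-nitrophenyl therefore holds for a third replacement (a 2.5-fold higher number from compound 1 to compound 4 (0.40 log units; beyond the scatter)), and compound 1 remains the strongest inhibitor of the four, with compounds 2, 3 and 4 forming one group that the assay does not separate. Nothing in the data shown explains why 4-nitrophenyl gives the lowest number.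

Still open, on these data alone, is whether the advantage of compound 1 belongs to the nitro group itself or to its placement, a question that 3-nitrophenyl on the same core would address. As far as these compounds go, it is equally open whether a different group at this spot, such as 4-aminophenyl, a phenyl carrying a carboxylic acid or one carrying a nitrile, would match compound 1 or fall in with the fluorine compounds.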